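The compounds below may be only part of what the source reports. "The series", "measured", "known", "first", "only" and "open" are said of these compounds alone.

Measured compounds:
Compound 1, `O=C1O[C@H]([C@@H](O)Cn2cc(-c3cccc(O)c3)nn2)C(OCc2ccccc2)=C1OCc1ccccc1`, gives 54100 nM in a functional assay on CFPAC-1 cells (Homo sapiens) for antiproliferative activity, read by MTT assay, with a stated time of 72 h; a lower number here means a stronger inhibitor, a higher number a weaker inhibitor.
Compound 2, `C[Si](C)(C)c1cn(C[C@H](O)[C@H]2OC(=O)C(OCc3ccccc3)=C2OCc2ccccc2)nn1`, gives 52600 nM in this assay.
Compound 3, `O=C1O[C@H]([C@@H](O)Cn2cc(CCO)nn2)C(OCc2ccccc2)=C1OCc1ccccc1`, gives in this assay only a limit, > 100000 nM, and no number.

Among the measured compounds shown here, compound 3 therefore stands at the edge of what this assay reports: it sits at the limit of > 100000 nM in this assay, at which 1 of the 3 values shown sits, the only one of the three values for which no number was obtained, while compounds 1 and 2 sit within the scatter of each other. The step to compound 4, `COc1ccccc1-c1cn(C[C@H](O)[C@H]2OC(=O)C(OCc3ccccc3)=C2OCc2ccccc2)nn1`, is this change: 2-methoxyphenyl in place of 2-hydroxyethyl on an aromatic carbon. Two measured steps speak to it. From compound 1 to compound 3 the step was an at least 1.8-fold higher number from compound 1 to compound 3 (0.26 log units; that floor lies within the scatter), and from compound 2 to compound 3 it was an at least 1.9-fold higher number from compound 2 to compound 3 (0.27 log units; that floor lies within the scatter); in both, 2-hydroxyethyl took the place of a larger group on that aromatic carbon and the number rose to the limit. Compound 4 runs the other way, bringing an aromatic ring back to the same carbon, so a lower number than compound 3 is expected, though the floors of those two steps lie within the scatter and the size is uncertain. Compound 4 is estimated at 50000 nM, with a likely range from 25000 nM to 110000 nM, which means an expected step of an at least 2.0-fold lower number from compound 3 to compound 4 (0.30 log units; that floor lies within the scatter).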

Compound 4, half-maximal inhibitory concentration: > 100000 nM
Compound 4: only a limit was reported (the forecaster's own chance of this, stated with the estimate: 30%); at least 2.0-fold (0.30 log units) between middle value and limit.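

Compound 4 gives only a limit in this assay, which shows that an aromatic ring on this carbon does not by itself bring back a measurable number: the limit of > 100000 nM in this assay, at which 2 of the 4 values shown sit. Putting 2-methoxyphenyl in place of 3-hydroxyphenyl gives an at least 1.8-fold higher number from compound 1 to compound 4 (0.26 log units; that floor lies within the scatter), and the ring-bearing group in place of the silicon-bearing group gives an at least 1.9-fold higher number from compound 2 to compound 4 (0.27 log units; that floor lies within the scatter), so neither step can be called a real loss, although each ends at a limit rather than a number. The step between the limits of compound 3 and compound 4 cannot be read, and the ring-free group of compound 2 goes against any simple rule that a ring on this carbon decides the outcome.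

Because 3-hydroxyphenyl and 2-methoxyphenyl differ both in the group on the ring and in where it sits, the compounds shown cannot separate these two changes; 3-methoxyphenyl or 2-hydroxyphenyl on the same carbon would address that. Going by these compounds, how an unsubstituted phenyl, an amine or a carboxylic acid at this place would read in this assay also stays open.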